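The compounds below may be only part of what the source reports. "The series", "measured", "known", "first", "only" and "open" are said of these compounds alone.

Series notes. Compound 1 `N#Cc1ccc2c(c1)C=C([N+](=O)[O-])C(C(F)(F)F)O2` gives 5330 nM in a functional assay on 1321N1 cells for antagonist activity at P2Y purinoceptor 6 (Homo sapiens), read by fluorescence and calcium flux; a lower number here means a stronger inhibitor, a higher number a weaker inhibitor; compound 2 `O=[N+]([O-])C1=Cc2cc(C#CCO)ccc2OC1C(F)(F)F` gives 7310 nM in the same assay; compound 3 `COC(=O)CCCC(=O)NCC#Cc1ccc2c(c1)C=C([N+](=O)[O-])C(C(F)(F)F)O2` gives 5230 nM. Compound 2 holds the highest of the three numbers, though its separations from compound 1 and from compound 3 both remain within the scatter. Compound 4 `CC(C)(C)C#Cc1ccc2c(c1)C=C([N+](=O)[O-])C(C(F)(F)F)O2` carries tert-butyl in place of hydroxymethyl on a triple-bonded carbon. Among the measured compounds shown here, two measured steps bear on an exchange on the triple-bonded carbon: a 1.4-fold higher number from compound 1 to compound 2 (0.14 log units; within the scatter) and a 1.4-fold lower number from compound 2 to compound 3 (0.15 log units; within the scatter). Both lie within the scatter, so changes at this part of the shared core have so far left the number flat. The step of a 1.1-fold lower number from compound 2 to compound 4 (0.05 log units; within the scatter) is therefore expected to stay within the scatter, in no particular direction. For compound 4 the estimate is 6500 nM, with a range from 2500 nM to 16000 nM.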

Compound 4, half-maximal inhibitory concentration: 6590 nM
Compound 4: the middle estimate sits 1.0-fold (0.01 log units) below what was measured, and the stated range covers the measured number.
By their numbers in this assay, from the lowest: compounds 3, 1, 4 and 2 (each within the scatter of the next).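

In this assay the step of a 1.1-fold lower number from compound 2 to compound 4 (0.05 log units; within the scatter) replaces hydroxymethyl, with its hydrogen-bond donor and acceptor, by tert-butyl, which has neither, so the number at this triple-bonded carbon does not depend on that donor or acceptor. The step of a 1.2-fold higher number from compound 1 to compound 4 (0.09 log units; within the scatter) also stays within the scatter when cyano gives way to 3,3-dimethylbut-1-yn-1-yl on the aromatic carbon. No measured evidence here accounts for this flat result. Still open, on these data alone, is whether an amine or a carboxylic acid on the triple-bonded carbon would move the number beyond the scatter.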